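A few compounds are considered here, and "the series" means these few. Any claim that something is new, unique, unknown or untested is made for them only; others in the source may bear on it.

Of the compounds shown here, three from this study have been measured in an ADME assay on HEK293 cells (Homo sapiens) for cytotoxicity, read by CCK-8 assay and cell counting, with a stated time of 2 days; on this read-out higher numbers stand for weaker inhibition and lower numbers for stronger inhibition. Compound 1 `Oc1ccc(-c2cc(-c3ccccc3)nc(-c3ccccc3Cl)c2)cc1` gives 3930 nM in this assay, and compound 2 `Oc1ccc(-c2cc(-c3ccco3)nc(-c3ccccc3Cl)c2)cc1` gives 4310 nM. The change between them is furan-2-yl in place of phenyl on an aromatic carbon, and it produced a 1.1-fold higher number from compound 1 to compound 2 (0.04 log units; within the scatter). Compound 3 `Oc1cccc(-c2cc(-c3ccccc3)nc(-c3ccc(Cl)cc3)c2)c1` gives 11600 nM, the highest of the three numbers; the difference between its core and the core of compound 1 is not broken down here, the two holding the same atoms joined differently.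

Compound 4 `Oc1cccc(-c2cc(-c3ccc(Cl)cc3)nc(-c3ccco3)c2)c1` has not yet been measured. It arises from compound 3 by furan-2-yl in place of phenyl on an aromatic carbon. Within the data shown here, this is the same kind of change as the one from compound 1 to compound 2, though the surroundings differ: in the earlier pair the position was meta to a 2-chlorophenyl group and meta to a 4-hydroxyphenyl group, while here it is meta to a 3-hydroxyphenyl group and meta to a 4-chlorophenyl group. Because the earlier step gave a 1.1-fold higher number from compound 1 to compound 2 (0.04 log units; within the scatter), a step of a 1.1-fold higher number from compound 3 to compound 4 (0.03 log units; within the scatter) is expected here. Compound 4 is therefore estimated at 12500 nM, with a likely range from 6000 nM to 26000 nM.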

Compound 4, half-maximal inhibitory concentration: 8190 nM
Compound 4: the middle estimate sits 1.5-fold (0.18 log units) above what was measured, within the range that was stated.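

In this assay, furan-2-yl in place of phenyl next to the ring nitrogen gives a 1.4-fold lower number from compound 3 to compound 4 (0.15 log units; within the scatter), so on this second core the change again leaves the number within the scatter. Set beside the step on the first core, the new step does not differ from it: the same change on two cores in this assay, a 1.1-fold higher number (0.04 log units; within the scatter) from compound 1 to compound 2 and a 1.4-fold lower number (0.15 log units; within the scatter) from compound 3 to compound 4, 1.6-fold (0.19 log units) apart, within the scatter of two such steps. Among these compounds, this shows that on these two cores the change can be carried across with no step beyond the scatter in this read-out, but with only two pairs it does not show that the same would hold on any other core, or in any other assay.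

The compounds shown leave open how an amine, a carboxylic acid or a longer chain would read in this assay at the place now held by phenyl or furan-2-yl. They also leave open what a methoxy group in place of the hydroxyl of the hydroxyphenyl ring would do to the number.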